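The source may hold more compounds than are shown below. What is called first, only, known or untested is meant among the compounds shown, and "the series" means these compounds.

Series notes. In a functional assay on ECV-304 cells (Homo sapiens), read by MTT assay, with stated times of 24 h and 12 h, tested at 12.5 uM (on this read-out higher numbers stand for a stronger effect at the one concentration tested and lower numbers for a weaker effect), three compounds have been measured so far. Compound 1 `Cc1nc(C)c(COc2ccccc2C(=O)O)nc1C` gives 14.1%. Compound 2 `Cc1nc(C)c(COC(=O)CCCC[C@@H]2CCSS2)nc1C` gives -60%, a negative number on this read-out. Compound 3 `Cc1nc(C)c(COc2ccc3ccc(=O)oc3c2)nc1C` gives 38.8%, the highest of the three numbers; its gap to compound 1 and its wider gap to compound 2 both lie beyond the scatter, so compound 3 is the most active of the three measured.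

Compound 4 `Cc1nc(C)c(COc2ccc3c(C)cc(=O)oc3c2)nc1C` is next for this assay and has not been measured. Against compound 3 it differs in one place: methyl in place of hydrogen on an aromatic carbon. Among the measured compounds shown here, no step between measured compounds shows what methyl in place of hydrogen does on the shared core of compound 3, so the expectation rests on compound 3 alone, at 38.8%. The step expected here is a number 3.2 percentage points higher from compound 3 to compound 4 (within the scatter), which stays within the scatter and does not point clearly in either direction. For compound 4 the estimated value in this assay is 42%, with a range from 22% to 62%.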

Compound 4, a percentage reported as activity, at one concentration (the size of the read-out at that concentration, not a potency): 12%
Beside the measured number, compound 4's estimate is 30 percentage points above it; the measured number lies below the stated range.
By their numbers in this assay, from the lowest: compound 2; then compounds 4 and 1 (each within the scatter of the next); then compound 3.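

In this assay, among the compounds shown here, methyl in place of hydrogen on an aromatic carbon opposite the ring oxygen gives a number 26.8 percentage points lower from compound 3 to compound 4 (beyond the scatter) and provides the first reading of this change on the shared core. The step shows that this position is sensitive to the change: an entering group of 1 heavy atom, with no hydrogen-bond donors, no hydrogen-bond acceptors and no net charge, is enough to move the number beyond the scatter. Nothing available bears on why the number moves, so the step stands as an observation only.

As far as these compounds go, whether an ethyl, a methoxy or an amine at this same place would lower the number as well remains open. A single step on one core also leaves open whether methyl would act alike on other aromatic carbons.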